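From Compound 1 to Compound 4: a Morpholine Amide

The source may report more compounds than this note shows. Statements on the series, on what has been measured and on what is new or still open speak of the compounds shown alone.

Measured so far, in a functional assay on 143B cells (Homo sapiens) for inhibition, read by MTT assay, with a stated time of 72 h; on this read-out lower numbers stand for stronger inhibition and higher numbers for weaker inhibition:
compound 1, `COc1ccccc1NC(=O)CCC(=O)OCCCCCCSc1ccc([N+](=O)[O-])c2nonc12`: 2120 nM
compound 2, `CCN(CC)CCCNC(=O)CCC(=O)OCCCCCCSc1ccc([N+](=O)[O-])c2nonc12`: 3440 nM
compound 3, `O=C(CCC(=O)OCCCCCCSc1ccc([N+](=O)[O-])c2nonc12)NCCN1CCCC1`: 5580 nM

Compound 1 stands at the lowest of the three numbers in this assay. Compound 2 lies a 1.6-fold higher number from compound 1 to compound 2 (0.21 log units; within the scatter), which is within the scatter, so the two cannot be ordered. Compound 3 lies a 2.6-fold higher number from compound 1 to compound 3 (0.42 log units; beyond the scatter), a modest step beyond the scatter. Between compound 2 and compound 3 the gap is a 1.6-fold higher number from compound 2 to compound 3 (0.21 log units; within the scatter), again within the scatter.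

Compound 4, `O=C(CCC(=O)N1CCOCC1)OCCCCCCSc1ccc([N+](=O)[O-])c2nonc12`, has not yet been measured. It differs from compound 1 in one place: morpholin-4-yl in place of (2-methoxyphenyl)amino on a carbonyl carbon. The same difference, cut one bond further out, reads (2-methoxyphenyl)carbamoyl to (morpholin-4-yl)carbonyl.

The two measured steps that bear on this both start from compound 1 and exchange the 2-methoxyphenyl on the amide-type nitrogen for a saturated group, 3-(diethylamino)propyl or 2-(pyrrolidin-1-yl)ethyl. One step was within the scatter and the other modestly beyond it, both towards higher numbers. Compound 4 makes an exchange of the same kind, so a small rise in the number, at most modest, is expected, with no strong case for either direction beyond the scatter.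

Compound 4 is therefore expected to give about 3500 nM, with a range of 1600 nM to 8000 nM. That expected step is a 1.7-fold higher number from compound 1 to compound 4 (0.22 log units; within the scatter).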

Compound 4, half-maximal inhibitory concentration: 1530 nM
For compound 4 the middle estimate is 2.3-fold (0.36 log units) above the measured one; the whole stated range lies above it.
By their numbers in this assay, from the lowest: compounds 4, 1, 2 and 3 (each within the scatter of the next, the first and the last beyond it).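

In this assay, within the data shown here, this position on the carbonyl carbon tolerates more than the earlier compounds showed: the (2-methoxyphenyl)amino group, with its aromatic ring and its hydrogen-bond donor, can give way to morpholin-4-yl, a non-aromatic ring with 0 hydrogen-bond donors, and the result stays within the scatter (a 1.4-fold lower number from compound 1 to compound 4 (0.14 log units; within the scatter)). Not every non-aromatic group behaves alike here, since the morpholine amide separates from both amine-bearing side chains by more than the scatter (a 2.2-fold lower number from compound 2 to compound 4 (0.35 log units; beyond the scatter) and a 3.6-fold lower number from compound 3 to compound 4 (0.56 log units; beyond the scatter)), so the outcome depends on the particular group and not simply on losing the aromatic ring. No measurement is available that would explain why the numbers fall as they do.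

Still open, going by these compounds, is which part of the morpholine ring matters, a question that a piperidin-1-yl group, lacking the ring oxygen, or a piperazin-1-yl group, with a second ring nitrogen, could address at the same carbonyl carbon. Also open, on these data alone, is whether a free carboxylic acid at this carbon, or a longer chain in place of the hexyl chain of the shared core, would keep the number in this range.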